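A few compounds are considered here, and "the series" means these few. Any claim that something is new, unique, unknown or untested is made for them only; others in the source may bear on it.

Measured compounds:
- compound 1 `CCCCN(CC)c1cc(C)nc2c1NC(=O)CN2c1ccc(C)cc1C`: 6.8%
- compound 2 `CCCCN(CC)c1cc(C)nc2c1NC(=O)CN2c1ccc(C(C)C)cc1Br`: 0.7%
- compound 3 `CCCCN(CC)c1cc(C)nc2c1NC(=O)CN2c1ccc(Br)cc1Cl`: "not determined" (no result reported)

The three compounds share one core and differ in the substituents on the aryl group attached to the ring nitrogen. All were examined in an assay on HEK-293T cells for displacement of a labelled ligand from corticotropin-releasing factor receptor 2 (Homo sapiens), read by scintillation counting, with a stated time of 2 h, tested at 1 uM; on this read-out higher numbers stand for more inhibition at the one concentration tested (going by the name of the read-out) and lower numbers for less inhibition. In this assay compound 1 gives 6.8%. Compound 2, carrying isopropyl and bromo groups on that aryl ring, gives 0.7% in this assay, and these two numbers lie within the scatter of each other, so nothing separates them. As far as these compounds go, compound 3 stands apart: for it this assay reported no number at all, so its place among the others is unknown.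

Compound 4 `CCCCN(CC)c1cc(C)nc2c1NC(=O)CN2c1ccc(Br)cc1Br` has not yet been measured. Its relation to compound 3 is bromo in place of chloro on an aromatic carbon. Within the data shown here, since compound 3 has no value, no step between the two can be sized, and the only anchor is that both measured analogues sit near the floor of this assay. On that basis compound 4 is expected to give a low inhibition as well, with the estimate 4% and a range from -8% to 18% in this assay.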

Compound 4, a percentage reported as inhibition, at one concentration (the size of the read-out at that concentration, not a potency): 9.4%
Compound 4: the middle estimate sits 5.4 percentage points below what was measured, and the stated range covers the measured number.
By their numbers in this assay, from the lowest: compounds 2, 1 and 4 (each within the scatter of the next).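

Compound 3 has no number in this assay and the step from chloro to bromo on this aromatic carbon, ortho to a large group, cannot be read, but compound 4 now gives a measured value for a 2,4-dibromophenyl group at the same place on the shared core. Bromo in place of isopropyl on an aromatic carbon gives a number 8.7 percentage points higher from compound 2 to compound 4 (within the scatter) and 2,4-dibromophenyl in place of 2,4-dimethylphenyl gives a number 2.6 percentage points higher from compound 1 to compound 4 (within the scatter) so neither change separates the compounds, and these three aryl groups cannot be told apart in this assay at the one concentration tested. No further measurement bears on why these numbers fall as they do.

As far as these compounds go, what chloro itself does at this place stays open, as compound 3 offers no number to set against compound 4. Also open, from the compounds shown here alone, is whether a methoxy group, an amine or a carboxylic acid on this aryl ring, or a longer chain in place of the butyl group on the amine of the core, would give a number that stands apart from these three in this assay at all.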